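The compounds below may be only part of what the source reports. "The series", "measured", "known", "first", "only" and "open" are said of these compounds alone.

Three compounds on a shared core have numbers in a functional assay on MCF7 cells (Homo sapiens) for antiproliferative activity, read by sulforhodamine B assay, with a stated time of 48 h; a higher number here means a weaker inhibitor, a lower number a stronger inhibitor. Compound 1 `COc1ccc(/C=C/C(=O)c2ccccc2-c2ccc(OC)c(OC)c2)cc1OC` gives 4900 nM. Compound 2 `COc1ccc(/C=C/C(=O)c2ccccc2-c2ccc(F)cc2)cc1` gives 670 nM. Compound 3 `COc1ccc(/C=C/C(=O)c2ccccc2-c2ccc(F)cc2)cc1OC` gives 240 nM, the lowest of the three. Compound 4 `COc1cc(/C=C/C(=O)c2ccccc2-c2ccc(F)cc2)ccc1O` has not yet been measured. It differs from compound 3 by hydrogen in place of methyl on an oxygen on an aromatic ring, or methoxy to hydroxy. Among the compounds with values here, no measured step makes this exchange. The large step of a 20-fold lower number from compound 1 to compound 3 (1.31 log units; beyond the scatter), with 4-fluorophenyl in place of 3,4-dimethoxyphenyl, concerns a group that stays unchanged here, so it offers little guidance. The closer guide is the modest step of a 2.8-fold lower number from compound 2 to compound 3 (0.45 log units; beyond the scatter), with methoxy in place of hydrogen on an aromatic carbon. Removing a methyl from a methoxy is therefore expected to cost about that much, a modest move toward a higher number in this assay, though this is uncertain. The expected step is a 2.3-fold higher number from compound 3 to compound 4 (0.36 log units; beyond the scatter). For compound 4 the estimated value is 550 nM, with an expected range from 170 nM to 1700 nM.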

Compound 4, half-maximal inhibitory concentration: 4000 nM
Estimate against measurement, compound 4: 7.3-fold (0.86 log units) below, and the stated range ends below it.
By their numbers in this assay, from the lowest: compound 3; then compound 2; then compounds 4 and 1 (each within the scatter of the next).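

Methoxy to hydroxy at this oxygen gives a 17-fold higher number from compound 3 to compound 4 (1.22 log units; beyond the scatter) in this assay and so counts for far more than the modest step of a 2.8-fold lower number from compound 2 to compound 3 (0.45 log units; beyond the scatter) had suggested for a methoxy on this ring. Although only a methyl leaves and the oxygen stays, the step is large, of the same order as a 20-fold lower number from compound 1 to compound 3 (1.31 log units; beyond the scatter) for the exchange of a whole aryl group. Nothing available accounts for the size of this step.

The compounds shown leave open whether an ethoxy group on this oxygen, or an amine in place of the hydroxy, would stay near compound 3 or near compound 4. They also leave open whether the same exchange at the other methoxy on this ring would cost as much.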